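The source may report more compounds than this note shows. Statements on the series, on what has been measured and on what is new or still open speak of the compounds shown alone.

Compound 1 `CCCCCCCCCCCCCC[C@@H](O)[C@@H](O)[C@H](CO)n1cc(CCCCCC)nn1` gives 12000 nM in a functional assay on HCT-116 cells (Homo sapiens) for cytotoxicity, read by sulforhodamine B assay; on this read-out higher numbers stand for an effect only at larger amounts of compound and lower numbers for an effect already at smaller amounts. Compound 2 `CCCCCCCCCCCCCC[C@@H](O)[C@@H](O)[C@H](CO)n1cc(CCCCCCCCCCCCC)nn1` reaches only a limit of this assay, > 50000 nM. The step of an at least 4.1-fold higher number from compound 1 to compound 2 (0.61 log units; beyond the scatter) thus reads as weaker activity with the longer chain, though its size is open because of the limit of > 50000 nM in this assay, at which 1 of the 2 values shown sits. Compound 3 `CCCCCCCCCCCCCC[C@@H](O)[C@@H](O)[C@H](CO)n1cc(CCC)nn1` differs from compound 2 by hydrogen in place of decyl on a saturated chain carbon, three bonds along the chain from an aromatic carbon. Since that earlier step bears directly on shortening the chain, the step of an at least 5.0-fold lower number from compound 2 to compound 3 (0.69 log units; beyond the scatter) is expected to run the other way, toward a lower number. Compound 3 is therefore estimated at 10000 nM, within 3000 nM to 40000 nM.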

Compound 3, half-maximal effective concentration: 13900 nM
Beside the measured number, compound 3's estimate is 1.4-fold (0.14 log units) below it; the measured number falls inside the stated range.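

Taking decyl off at this place, on a saturated chain carbon, three bonds along the chain from an aromatic carbon, gives an at least 3.5-fold lower number from compound 2 to compound 3 (0.55 log units; beyond the scatter) in this assay, so the shift seen with the longest chain reverses when the chain is shortened. Taking off propyl at the same place gives a 1.2-fold higher number from compound 1 to compound 3 (0.06 log units; within the scatter), so the two shorter chains do not separate on this read-out. The size of the first step stays open: the limit of > 50000 nM in this assay, at which 1 of the 3 values shown sits.

Where between these chain lengths the number starts to rise stays open, as does whether an amine or a carboxylic acid in place of this chain would move it.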